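The source may report more compounds than this note shows. Statements on the series, on what has been measured and on what is new or still open speak of the compounds shown alone.

The measured compounds:

Compound 1, `CCOC(=O)c1ccc(-c2nn(C)c3ccccc23)cc1`, gives 270 nM in a functional assay on cells (Platelet, Homo sapiens) for inhibition; on this read-out higher numbers stand for weaker inhibition and lower numbers for stronger inhibition.
Compound 2, `CCOC(=O)c1ccc(-c2nn(CC)c3ccccc23)cc1`, gives 360 nM in this assay.
Compound 3, `CCNC(=O)c1ccc(-c2nn(Cc3ccccc3)c3ccccc23)cc1`, gives 5640 nM in this assay.

Compounds 1 and 2 share one core and differ by a single change, (methyl in place of hydrogen on a saturated chain carbon bound to an aromatic nitrogen). That change gave a 1.3-fold higher number from compound 1 to compound 2 (0.12 log units; within the scatter), so on this evidence adding the methyl at that place hardly moved the result. Compound 3 carries a different core; the difference between the two cores is not broken down here, and its number is the highest of the three.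

Compound 4, `CCCNC(=O)c1ccc(-c2nn(Cc3ccccc3)c3ccccc23)cc1`, has not yet been measured. It differs from compound 3 by methyl in place of hydrogen on a saturated chain carbon, two bonds along the chain from an amide-type nitrogen. Among the compounds with values here, this is the same kind of change as the one from compound 1 to compound 2, but it sits elsewhere: there the saturated chain carbon is bound to an aromatic nitrogen, here it is two bonds along the chain from an amide-type nitrogen. Since the earlier step was a 1.3-fold higher number from compound 1 to compound 2 (0.12 log units; within the scatter), a comparably small step is expected here, a 1.2-fold higher number from compound 3 to compound 4 (0.06 log units; within the scatter), with added uncertainty because the place differs. Compound 4 is therefore estimated at 6500 nM in this assay, with a likely range from 3000 nM to 14000 nM.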

Compound 4, half-maximal inhibitory concentration: > 10000 nM
Compound 4 gave a limit, no number; the forecaster's own chance of this, stated with the estimate: 5%; at least 1.5-fold (0.18 log units) between middle value and limit.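

In this assay compound 4 gives > 10000 nM, which is a limit of the assay and not a number. As far as these compounds go, the new step can therefore be read only as a floor, and its true size stays unknown: an at least 1.7-fold higher number from compound 3 to compound 4 (0.24 log units; that floor lies within the scatter). Set beside the earlier step, this neither proves that adding the methyl has an effect of the same size on both cores nor proves that the effect depends on the core, and two pairs of compounds could not establish a general rule in any case: the same change on two cores in this assay, a 1.3-fold higher number (0.12 log units; within the scatter) from compound 1 to compound 2 and an at least 1.7-fold higher number (0.24 log units; that floor lies within the scatter) from compound 3 to compound 4; the limit leaves it open whether they differ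

The compounds shown leave open how large the step from ethylamino to propylamino really is, and a measured number for compound 4 in place of the limit would be needed to settle that. They also leave open what a longer chain than propyl, or an amine at the end of that chain, would do to the result in this assay.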